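Series notes: substituents on the aromatic nitrogen

This account rests on a few compounds, and the source may have more. Where it says the series, first, only, none or still open, it means among the compounds named here.

Measured so far:
compound 1 `CCCCCn1ccc2cc(/C(C)=C/C(=O)Nc3ccccc3OCCCC(=O)O)ccc21` — 23 nM
compound 2 `C/C(=C\C(=O)Nc1ccccc1OCCCC(=O)O)c1ccc2c(ccn2CC(C)C)c1` — 160 nM
compound 3 `CCCC(C)n1ccc2cc(/C(C)=C/C(=O)Nc3ccccc3OCCCC(=O)O)ccc21` — 7.8 nM

In an assay on Prostate gland for inhibition of steroid 5-alpha-reductase (Rattus norvegicus) (a lower number here means a stronger inhibitor, a higher number a weaker inhibitor), compound 3 gives the lowest number of the three and stands as the strongest inhibitor, since its steps to the other two are both beyond the scatter: a 2.9-fold lower number from compound 1 to compound 3 (0.47 log units; beyond the scatter) and a 21-fold lower number from compound 2 to compound 3 (1.31 log units; beyond the scatter). Compound 4 `C/C(=C\C(=O)Nc1ccccc1OCCCC(=O)O)c1ccc2c(ccn2Cc2ccc(C)cc2)c1` has not been measured; it differs from compound 3 by 4-methylbenzyl in place of 1-methylbutyl on an aromatic nitrogen. The measured steps all change saturated chains on this nitrogen: a 7.0-fold higher number from compound 1 to compound 2 (0.84 log units; beyond the scatter), and the two steps into compound 3 already given, both of which end at the lowest number. Among the measured compounds shown here, no step so far puts a ring on the nitrogen, so the change to 4-methylbenzyl is not covered directly. In compound 3 the 1-methylbutyl group goes with 7.8 nM. Compound 4 drops that group, so a step back towards weaker inhibition is expected, about a 5.1-fold higher number from compound 3 to compound 4 (0.71 log units; beyond the scatter). The expected value for compound 4 is 40 nM, with a range of 10 nM to 160 nM.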

Compound 4, half-maximal inhibitory concentration: 88 nM
Compound 4: middle estimate off by 2.2-fold (0.34 log units), on the low side; measured number inside the range.
By their numbers in this assay, from the lowest: compound 3; then compound 1; then compounds 4 and 2 (each within the scatter of the next).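

In this assay, the first ring on this aromatic nitrogen gives an 11-fold higher number from compound 3 to compound 4 (1.05 log units; beyond the scatter), so 4-methylbenzyl does not keep the level reached with the branched 1-methylbutyl group. The ring-bearing group also reads weaker than the straight pentyl group, with a 3.8-fold higher number from compound 1 to compound 4 (0.58 log units; beyond the scatter), while a 1.8-fold lower number from compound 2 to compound 4 (0.26 log units; within the scatter) lies within the scatter, so 4-methylbenzyl and isobutyl cannot be separated here. Nothing at hand explains these differences.

On these data alone, it remains open whether the methyl of 4-methylbenzyl matters, which a plain benzyl group would show, and whether a 1-phenylethyl group, with a ring and a branch on the saturated chain carbon bound to the aromatic nitrogen, would read closer to compound 3. As far as these compounds go, how a chain ending in an amine would behave on this nitrogen also stays open.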